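The compounds below may be only part of what the source reports. "The series", "measured", "known", "first", "only" and "open" are said of these compounds alone.

Compound 1 `CCN(Cc1cccn1C)C(=O)COc1ccc(C)cc1` carries a 1-methyl-1H-pyrrol-2-yl group on a saturated chain carbon bound to an amide-type nitrogen. For the measured compounds named here, in an assay on HEK293 cells for agonist activity at transient receptor potential cation channel subfamily M member 8 (Homo sapiens), read by fluorescence and calcium flux, with a stated time of 15 min (on this read-out lower numbers stand for an effect already at smaller amounts and higher numbers for an effect only at larger amounts of compound), compound 1 gives 21300 nM, the only number recorded here, which places its effect at large amounts of compound. Compound 2 `CCN1C(=O)C(Oc2ccc(C)cc2)C1c1cccs1` is recorded in this assay only as "active" (no number reported), without a number, so no size can be drawn from it. Compound 3 `CCN(Cc1cc[nH]n1)C(=O)COc1ccc(C)cc1` is not yet measured. It differs from compound 1 in one place: 1H-pyrazol-3-yl in place of 1-methyl-1H-pyrrol-2-yl on a saturated chain carbon bound to an amide-type nitrogen. Going by the values given here, no step between two measured compounds exists in this set, so nothing shows how far such an exchange moves the read-out. With only the value of compound 1 as an anchor, the step is expected to stay within the usual scatter, with no clear direction, as a 1.1-fold lower number from compound 1 to compound 3 (0.03 log units; within the scatter). Compound 3 is therefore estimated at 20000 nM, within 6000 nM to 60000 nM.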

Compound 3, half-maximal effective concentration: "not active" (no number reported)
No number was reported for compound 3; no gap can be computed for the estimate.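

For the compounds shown here, compound 3 has no reported number, so no step from compound 1 to compound 3 can be read. The compounds shown leave open how far, and in which direction, exchanging 1-methyl-1H-pyrrol-2-yl for 1H-pyrazol-3-yl moves the read-out. No measured evidence bears on this result.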